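The compounds below may be only part of what the source reports. "The series", "measured", "known", "first", "only" and "open" are said of these compounds alone.

Measured in a functional assay on K562 cells (Homo sapiens) for antiproliferative activity, read by MTT assay, with a stated time of 48 h; on this read-out higher numbers stand for weaker inhibition and lower numbers for stronger inhibition:
- Compound 1 `COC(=O)[C@H](CC(C)C)NC(=O)c1ccc(Oc2nc3ccccc3nc2NC(C)(C)C)cc1`: > 50000 nM (a limit)
- Compound 2 `CCCCCCCCCCCCNc1nc2ccccc2nc1Oc1ccc(C(=O)N[C@H](C(=O)O)[C@H](C)CC)cc1`: 21500 nM
- Compound 3 `CC(C)(C)Nc1nc2ccccc2nc1Oc1ccc(C(=O)NCC(=O)O)cc1`: > 50000 nM (a limit)

Compound 3 has only a limit and no number, and it sits at the limit of > 50000 nM in this assay, at which 2 of the 3 values shown sit. Compound 4 `CC[C@@H](C)[C@H](NC(=O)c1ccc(Oc2nc3ccccc3nc2NC(C)(C)C)cc1)C(=O)O` differs from compound 3 by sec-butyl in place of hydrogen on a saturated chain carbon bound to an amide-type nitrogen and a carbonyl carbon.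

Within the data shown here, one measured step touches this place, a step that the two limits leave unreadable from compound 1 to compound 3, and it gives no size. Among the measured compounds shown here, compound 2 gives 21500 nM, the only number, but it lies no single step from compound 3, so it sets no size for this change either.

No step beyond the scatter, in either direction, is therefore expected in this assay, and a further limit is the likeliest report. The expected change is a number no higher from compound 3 to compound 4 (the limit leaves the size open). For compound 4 the estimate is 50000 nM, with an expected range of 20000 nM to 100000 nM.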

Compound 4, half-maximal inhibitory concentration: 18300 nM
Compound 4: middle estimate off by 2.7-fold (0.44 log units), on the high side, and the stated range ends above it.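

In this assay, among these compounds, sec-butyl on the saturated chain carbon bound to an amide-type nitrogen and a carbonyl carbon gives the first readable step at this position: an at least 2.7-fold lower number from compound 3 to compound 4 (0.43 log units; beyond the scatter), and 1-carboxy-2-methylbutyl in place of 1-(methoxycarbonyl)-3-methylbutyl gives an at least 2.7-fold lower number from compound 1 to compound 4 (0.43 log units; beyond the scatter). Compound 3 has only a limit, and so does compound 1, so each of these sizes is a floor and not a measure: the limit of > 50000 nM in this assay, at which 2 of the 4 values shown sit.
With this side chain in place, tert-butyl in place of dodecyl on the nitrogen on an aromatic ring gives a 1.2-fold lower number from compound 2 to compound 4 (0.07 log units; within the scatter), which lies within the scatter.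

From the compounds shown here alone, it stays open whether sec-butyl is special at this carbon, or whether a methyl, isopropyl or benzyl group would serve as well. The step from compound 1 also changes the ester and the side chain together, so the methyl ester of the sec-butyl side chain would be needed to separate them.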